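Sulfonamide series: notes toward compound 4 in phosphatase inhibition

This account rests on a few compounds, and the source may have more. Where it says the series, first, only, none or still open, it means among the compounds named here.

Measured compounds and their values:
compound 1 `COc1ccc(Cl)cc1S(=O)(=O)Nc1cncc(C(=O)Nc2ccccc2)c1` gives 310 nM
compound 2 `COc1ccc(OC(F)(F)F)cc1S(=O)(=O)Nc1cncc(C(N)=O)c1` gives 131 nM
compound 3 `COc1ccc(C#N)cc1S(=O)(=O)Nc1cnc2ccccc2c1` gives 38 nM

All three values come from an assay on isolated protein for inhibition of alkaline phosphatase, tissue-nonspecific isozyme (Homo sapiens); on this read-out lower numbers stand for stronger inhibition and higher numbers for weaker inhibition. Compound 1 holds the highest number of the three at 310 nM. Its nearest neighbour is compound 2, whose number at 131 nM sits lower by a margin beyond the scatter. Furthest from compound 1 is compound 3, which gives 38 nM, lower still and also beyond the scatter. For the measured compounds named here, no two measured compounds differ in only one place, so no single step has been quantified in this assay.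

Compound 4 `COc1ccc(Cl)cc1S(=O)(=O)Nc1cncc(-c2cccc(C)c2)c1` has not been measured. It differs from compound 1 in one place: 3-methylphenyl in place of phenylcarbamoyl on an aromatic carbon. The hydrogen-bond donor and acceptor of the phenylcarbamoyl leave with it, and the 3-methylphenyl that enters sits directly on the core. Going by the values given here, the data hold no comparable step, so the size and direction of the change are open. The expectation is a step of modest size, within or near the scatter, in either direction, here given as a 1.2-fold lower number from compound 1 to compound 4 (0.09 log units; within the scatter). For compound 4 the estimated value in this assay is 250 nM, with a range from 80 nM to 800 nM.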

Compound 4, half-maximal inhibitory concentration: 160 nM
Compound 4: middle estimate off by 1.6-fold (0.19 log units), on the high side, and the stated range covers the measured number.
By their numbers in this assay, from the lowest: compound 3; then compounds 2, 4 and 1 (each within the scatter of the next, the first and the last beyond it).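

In this assay, for the compounds shown here, 3-methylphenyl in place of phenylcarbamoyl on this aromatic carbon gives a 1.9-fold lower number from compound 1 to compound 4 (0.29 log units; within the scatter), the first single-place step that can be read, and it stays within the scatter. At this carbon, two atoms from the ring nitrogen, the hydrogen-bond donor and hydrogen-bond acceptor of the phenylcarbamoyl can therefore leave, and the aromatic ring can sit directly on the core, without a change beyond the scatter on the core of compound 1. No measurement at hand speaks to why the two groups read alike here.

From the compounds shown here alone, what the aromatic ring itself contributes at this carbon remains open: a bare hydrogen, an amine or a carboxylic acid at the same place would separate the ring from the rest of the group, and a plain phenyl would isolate the methyl of compound 4. Also open, going by these compounds, is whether this step holds when the chlorine of compound 1 is replaced by a nitrile or a trifluoromethoxy group.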